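Turning over the ring configuration of compound 2

The compounds below may be only part of what the source reports. "The series", "measured", "known", "first", "only" and "open" are said of these compounds alone.

Compound 1 `CC(=O)Nc1cnc2[nH]c(=O)n([C@H]3CC[C@@H](C(C)(C)C)CC3)c(=O)c2c1`: 15 mL.min-1.g-1
Compound 2 `CC(=O)Nc1cnc2[nH]c(=O)n([C@H]3CC[C@H](C(C)C)CC3)c(=O)c2c1`: 1.4 mL.min-1.g-1

In an ADME assay on microsomes from liver (Mus musculus, strain CD1) for metabolic stability, read by HPLC, using NADPH, with a stated time of 30 min, tested at 0.5 uM (a lower number here means slower removal, a higher number faster removal of the compound), compound 2 gives 1.4 mL.min-1.g-1 and compound 1 gives 15 mL.min-1.g-1. The number for compound 2 is the lower of the two, and the gap between them lies beyond the scatter. Compound 3 `CC(=O)Nc1cnc2[nH]c(=O)n([C@H]3CC[C@@H](C(C)C)CC3)c(=O)c2c1` is built from the same atoms and bonds, and only its configuration as drawn changes: the two compounds have the same atoms and bonds and differ only in configuration as drawn: 2 of 2 stereo elements differ (all stereocentres are inverted: mirror images); a stereocentre at a saturated ring carbon is drawn r in compound 2 and s in compound 3; a stereocentre at a saturated ring carbon is drawn r in compound 2 and s in compound 3. Going by the values given here, no measured pair shows the effect of such a change, so any expectation is loose. With compound 2 at 1.4 mL.min-1.g-1, a rise seems likelier than a fall. The expected change is a 2.9-fold higher number from compound 2 to compound 3 (0.46 log units; beyond the scatter). For compound 3, the estimate is 4 mL.min-1.g-1, with an expected range of 1.2 mL.min-1.g-1 to 15 mL.min-1.g-1.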

Compound 3, intrinsic clearance in microsomes: 10 mL.min-1.g-1
The estimate for compound 3 lay 2.5-fold (0.40 log units) below the measured number, within the range that was stated.
By their numbers in this assay, from the lowest: compound 2; then compounds 3 and 1 (each within the scatter of the next).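

In this assay, configuration alone moves the number, with a 7.1-fold higher number from compound 2 to compound 3 (0.85 log units; beyond the scatter). The ring configuration therefore matters at this position, and the change in the number can be set on it alone because of this: the fact that compounds 2 and 3 differ only in the configuration as drawn. With the configuration of compound 3, hydrogen in place of methyl gives a 1.5-fold lower number from compound 1 to compound 3 (0.18 log units; within the scatter), so that chain change shows no clear effect here.

As far as these compounds go, it remains open whether the configuration of compound 2 would give a low number with other groups on that ring, such as an amine or a carboxylic acid.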